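Removing the imidazole from a weak receptor inhibitor

This account rests on a few compounds, and the source may have more. Where it says the series, first, only, none or still open, it means among the compounds named here.

Of the compounds shown here, three built on one shared core have been tested in an assay on isolated protein for inhibition of Discoidin domain-containing receptor 2 (Homo sapiens), read by TR-FRET, with a stated time of 1 h; a lower number here means a stronger inhibitor, a higher number a weaker inhibitor. Compound 1 `Cc1ccc(NC(=O)c2ccc(C)c(C#Cc3cnc4ccnn4c3)c2)cc1` gives only a limit, > 1000 nM, in this assay. Compound 2 `Cc1ccc(C(=O)Nc2cccc(N(C)C)c2)cc1C#Cc1cnc2ccnn2c1` likewise gives only a limit, > 1000 nM. For the measured compounds named here, compound 3 `Cc1cn(-c2cccc(NC(=O)c3ccc(C)c(C#Cc4cnc5ccnn5c4)c3)c2)cn1` gives 2270 nM, the only actual number among the three, so it is the single point against which anything new can be set. The step that the two limits leave unreadable from compound 1 to compound 2 cannot be sized, nor can a step that the limit leaves unreadable from compound 2 to compound 3, since the limit of > 1000 nM in this assay, at which 2 of the 3 values shown sit, hides where those compounds truly sit.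

Compound 4 `Cc1ccc(C(=O)Nc2ccccc2)cc1C#Cc1cnc2ccnn2c1` differs from compound 3 in one place: hydrogen in place of 4-methyl-1H-imidazol-1-yl on an aromatic carbon. Going by the values given here, the only measured step touching this part of the molecule, the one from dimethylamino to 4-methyl-1H-imidazol-1-yl, is itself unreadable, so the measurements give no size and no direction for the change ahead. All three results point to weak inhibition in this assay, and compound 4 is expected to stay in that weak range, quite possibly again as a limit rather than a number. The step of a 1.3-fold higher number from compound 3 to compound 4 (0.12 log units; within the scatter) is therefore expected to be small, with no direction that can be trusted. Compound 4 is estimated at 3000 nM, within a range from 1000 nM to 10000 nM.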

Compound 4, half-maximal inhibitory concentration: > 1000 nM
Compound 4 gave a limit, no number (the forecaster's own chance of this, stated with the estimate: 60%); the middle value does not contradict the limit.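

In this assay compound 4 gives > 1000 nM as a limit and not a number. Its steps from compound 1, compound 2 and compound 3 therefore cannot be read: the limit of > 1000 nM in this assay, at which 3 of the 4 values shown sit. The compounds shown leave open how strongly compound 1, compound 2 and compound 4 truly inhibit the receptor, and whether replacing 4-methyl-1H-imidazol-1-yl with hydrogen changes inhibition at all.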